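The source may hold more compounds than are shown below. What is called first, only, known or untested is meant among the compounds shown, and "the series" means these compounds.

Compound 1 `Oc1ccc(-c2cc(-c3ccsc3)cc(-c3ccc(O)cc3)n2)cc1` is measured in a functional assay on DU-145 cells (Homo sapiens) for cytotoxicity, read by CCK-8 assay (a lower number here means a stronger inhibitor, a higher number a weaker inhibitor), at 2060 nM. Compound 2 `Oc1ccc(-c2cc(-c3ccco3)cc(-c3ccccc3O)n2)cc1` gives in this assay only > 50000 nM, which is a limit of the assay and not a number. Compound 2 thus stands at the limit of > 50000 nM in this assay, at which 1 of the 2 values shown sits. Compound 3 `Oc1ccc(-c2cc(-c3ccco3)cc(-c3ccc(O)cc3)n2)cc1` has not been measured; it differs from compound 2 by 4-hydroxyphenyl in place of 2-hydroxyphenyl on an aromatic carbon. No measured pair shows this change, so no measured step can be quoted, and compound 1, which also carries 4-hydroxyphenyl groups, is the nearest comparison on the numbers shown. The step from compound 2 to compound 3 is expected to be large, toward a stronger inhibitor, as an at least 12-fold lower number from compound 2 to compound 3 (1.09 log units; beyond the scatter) shows. Compound 3 is estimated at 4000 nM in this assay, within 1000 nM to 30000 nM.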

Compound 3, half-maximal inhibitory concentration: > 50000 nM
Compound 3 gave a limit, no number; the forecaster's own chance of this, stated with the estimate: 20%; middle value at least 12-fold (1.09 log units) away from the limit.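

In this assay, furan-2-yl in place of thiophen-3-yl, with both 4-hydroxyphenyl groups kept, gives an at least 24-fold higher number from compound 1 to compound 3 (1.38 log units; beyond the scatter), so the group at this position clearly matters. Having 4-hydroxyphenyl next to the ring nitrogen is therefore not enough on its own to give a measurable value when furan-2-yl is present. Compound 2 and compound 3 both stand at a limit of the assay, so the step between them cannot be read: the limit of > 50000 nM in this assay, at which 2 of the 3 values shown sit.

On these data alone, how far past that limit either compound lies remains open. As far as these compounds go, it is also open whether an amine or a carboxylic acid in place of thiophen-3-yl would give a lower or a higher number.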